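The source may report more compounds than this note shows. Statements on the series, on what has been measured and on what is new or still open speak of the compounds shown alone.

Three members of this series have been tested, and a fourth awaits measurement. Compound 1 `COC(=O)c1cc(-c2cccc(NC(=O)c3ccc(/C=C/C(=O)c4ccccc4)cc3)c2)on1` was examined in an ADME assay on Vero cells (Chlorocebus sabaeus) for cytotoxicity, read by MTT assay, with a stated time of 72 h (on this read-out higher numbers stand for lower toxicity in this test and lower numbers for higher toxicity in this test), and gave > 50 ug/mL, which is a limit of the assay and not a number. Compound 2 `COC(=O)c1cc(-c2cccc(NC(=O)c3ccc(/C=C/C(=O)c4ccc(OC)cc4)cc3)c2)on1` gave in this assay > 10 ug/mL, again only a limit. Compound 3 `COC(=O)c1cc(-c2cccc(NC(=O)c3ccc(/C=C/C(=O)c4ccc(OC)cc4OC)cc3)c2)on1` gave in this assay > 50 ug/mL, also a limit. Compound 2 thus stands only at a limit, and the two other values shown are limits as well. None of the steps among the three can be read: a step that the two limits leave unreadable from compound 1 to compound 2, a step that the two limits leave unreadable from compound 1 to compound 3 and a step that the two limits leave unreadable from compound 2 to compound 3. What the numbers offer is the limit of > 10 ug/mL in this assay, at which 1 of the 3 values shown sits, and (the limit of > 50 ug/mL in this assay, at which 2 of the 3 values shown sit). Compound 4 `COC(=O)c1cc(-c2cccc(NC(=O)c3ccc(/C=C/C(=O)c4ccccc4Cl)cc3)c2)on1` differs from compound 2 in one place: 2-chlorophenyl in place of 4-methoxyphenyl on a carbonyl carbon. Among the compounds with values here, the measured steps bear on this change only in the sense that every one of them is hidden behind a limit, so no readable size is available, and no step in this assay beyond the scatter is expected in either direction; the three values together point to another limit. Compound 4 is therefore expected to give 50 ug/mL in this assay, within an estimated range from 15 ug/mL to 150 ug/mL. The step from compound 2 to compound 4 is estimated at a step that the limit leaves unreadable from compound 2 to compound 4.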

Compound 4, half-maximal cytotoxic concentration: > 25 ug/mL
Compound 4: only a limit was reported; the forecaster's own chance of this, stated with the estimate: 80%; the middle value lies beyond the limit too.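

In this assay, within the data shown here, compound 4 gave only a limit and not a number, and compounds 1, 2 and 3 also stand at limits, so no step from any of them to compound 4 can be read. The compounds shown leave open whether any of these changes on the carbonyl carbon alters the half-maximal cytotoxic concentration at all.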